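Urea in place of amide on a pyrazole anilide

The source may hold more compounds than are shown below. What is called first, only, known or untested is meant among the compounds shown, and "the series" means these compounds.

Measured so far:
Compound 1, `O=C(Nc1cccc(-n2cc(-c3ccncc3)c(-c3ccc(Cl)c(O)c3)n2)c1)Nc1cccc(C(F)(F)F)c1`: 2120 nM
Compound 2, `COc1cc(-c2nn(-c3cccc(NC(=O)c4cccc(C(F)(F)F)c4)c3)cc2-c2ccncc2)ccc1Cl`: 3240 nM

In a functional assay on TK-10 cells (Homo sapiens) for inhibition, read by sulforhodamine B assay, with a stated time of 48 h (on this read-out lower numbers stand for stronger inhibition of growth and higher numbers for weaker inhibition of growth), compound 1 gives 2120 nM, and compound 2 gives 3240 nM. Compound 2 stands at the higher of the two numbers, but the two values lie within the usual scatter of each other, so nothing can be said about which of the two inhibits growth more strongly.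

Compound 3, `COc1cc(-c2nn(-c3cccc(NC(=O)Nc4ccc(Cl)c(Cl)c4)c3)cc2-c2ccncc2)ccc1Cl`, is not yet measured. It differs from compound 2 in one place: (3,4-dichlorophenyl)amino in place of 3-(trifluoromethyl)phenyl on a carbonyl carbon. In plain words, the carbonyl that links to the aryl nitrogen carries a (3,4-dichlorophenyl)amino group instead of a 3-(trifluoromethyl)phenyl group, so the amide of compound 2 becomes a urea in compound 3. Among the measured compounds shown here, no measured pair shows this exact change on its own; compound 1 carries a urea but also differs elsewhere, so it gives no clean comparison. The expectation is therefore a small step, if any, with the number of compound 3 a little lower or unchanged within the scatter, a 1.6-fold lower number from compound 2 to compound 3 (0.21 log units; within the scatter).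

Compound 3 is estimated at 2000 nM, with a likely range from 700 nM to 6000 nM.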

Compound 3, concentration for 50% growth inhibition: 1430 nM
For compound 3 the middle estimate is 1.4-fold (0.15 log units) above the measured one; the range from low to high includes it.
By their numbers in this assay, from the lowest: compounds 3, 1 and 2 (each within the scatter of the next, the first and the last beyond it).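

In this assay, placing (3,4-dichlorophenyl)amino in place of 3-(trifluoromethyl)phenyl on the carbonyl carbon gives a 2.3-fold lower number from compound 2 to compound 3 (0.36 log units; beyond the scatter), a modest step but one that lies beyond the scatter. This shows that the group on this carbonyl carbon can affect growth inhibition, and that a urea carrying the dichlorophenyl ring is at least as well accepted here as the amide carrying the trifluoromethyl-substituted ring. The swap changes the link and the ring substituents together, adding one hydrogen-bond donor along the way, and no independent measurement is available to explain the step.

The compounds shown do not separate the contribution of the urea link from that of the two chlorines, and that would take a urea keeping the 3-(trifluoromethyl)phenyl ring or an amide carrying the 3,4-dichlorophenyl ring. On these data alone, it also remains open whether an aromatic ring is needed at this position at all, or whether a butyl chain, a morpholine or a ring bearing a carboxylic acid would be accepted on the same carbonyl carbon.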